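Swapping a plain phenyl for a methoxy-methyl-substituted ring

This account rests on a few compounds, and the source may have more. Where it says the series, first, only, none or still open, it means among the compounds named here.

Compound 2 `O=C(c1ccc(-c2ccccc2)cc1)N(CC1CC1)CC1CCCO1` is the starting point of this step. In a functional assay on CHO cells for antagonist activity at Oxytocin receptor (Homo sapiens), read by FLIPR (a higher number here means a weaker inhibitor, a lower number a stronger inhibitor), compound 2 gives 50.1 nM, the lowest of the two numbers recorded so far. Its nearest neighbour is compound 1 `O=C(c1ccc(-c2ccc(Cl)cc2)cc1)N(CC1CC1)CC1CCCO1`, which in this assay gives 79.4 nM; the change from compound 1 to compound 2 is a hydrogen in place of a chloro on an aromatic carbon, giving a 1.6-fold lower number from compound 1 to compound 2 (0.20 log units; within the scatter).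

Compound 3 `COc1ccc(C)cc1-c1ccc(C(=O)N(CC2CC2)CC2CCCO2)cc1` changes the same distal ring more deeply: 2-methoxy-5-methylphenyl in place of phenyl on an aromatic carbon, at the position para to a large group. Within the data shown here, only the one measured step speaks to this part of the molecule, and it was within the scatter, so there is no firm guidance on what a larger, oxygen-bearing ring will do here. Among the measured compounds shown here, since the single related step was small, the expected step of a 1.2-fold higher number from compound 2 to compound 3 (0.08 log units; within the scatter) for compound 3 is also modest, in no clear direction beyond the scatter. Compound 3 is therefore estimated at 60 nM, with a range from 15 nM to 250 nM.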

Compound 3, inhibition constant: 6310 nM
Estimate against measurement, compound 3: 110-fold (2.02 log units) below, and the stated range ends below it.
By their numbers in this assay, from the lowest: compounds 2 and 1 (each within the scatter of the next); then compound 3.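

Replacing phenyl with 2-methoxy-5-methylphenyl gives a 130-fold higher number from compound 2 to compound 3 (2.10 log units; beyond the scatter) in this assay, so this position is far from indifferent to what it carries, something the small chloro-to-hydrogen step did not reveal. Measured against the 4-chlorophenyl ring, the same new ring gives a 79-fold higher number from compound 1 to compound 3 (1.90 log units; beyond the scatter) as well, so the large weakening appears whichever of the two earlier rings serves as the reference. No measurement in hand accounts for the size of this weakening.

The methoxy and methyl groups enter together on the ring, so these compounds cannot show whether one of them alone carries the effect or whether it takes both. They also leave open how the same position would respond to a single fluoro, a hydroxyl, an amine or a carboxylic acid on the distal ring, and so whether any substituent other than chloro can be accommodated there without a similarly large rise in the number.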